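The source may hold more compounds than are shown below. What is called first, only, known or untested is meant among the compounds shown, and "the series" means these compounds.

Going by the values given here, compound 2 `COc1ccc(F)cc1N1C(=O)CSC1c1cccc(C(=O)NCCCCc2ccccc2)c1` is one of two compounds measured in a functional assay on U2OS cells (Homo sapiens) for inhibition, read by CCK-8 assay, with a stated time of 72 h, tested at 1 uM; on this read-out lower numbers stand for less inhibition and higher numbers for more inhibition at the one concentration tested (going by the name of the read-out). In this assay compound 2 gives 32%, and compound 1 `COc1ccc(C)cc1N1C(=O)CSC1c1cccc(C(=O)NCCCCc2ccccc2)c1` gives 30%. Among the compounds with values here, the single measured step between them, a number 2 percentage points higher from compound 1 to compound 2 (within the scatter), comes with fluoro in place of methyl on an aromatic carbon. On these two numbers compound 2 stands highest of the two, with compound 1 nearest to it, and the gap between them lies within the usual scatter, so no order between the two can be claimed.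

Compound 3 `COc1c(F)cccc1N1C(=O)CSC1c1cccc(C(=O)NCCCCc2ccccc2)c1` has not yet been measured in this assay. It differs from compound 2 by 3-fluoro-2-methoxyphenyl in place of 5-fluoro-2-methoxyphenyl on an amide-type nitrogen in a ring. Within the data shown here, the only measured step that touches this ring is the one from compound 1 to compound 2, which was within the scatter and concerned a different exchange, so there is no measured example of the fluorine changing its place on this ring. On that basis no step beyond the scatter is expected, and the expected step of a number 2 percentage points lower from compound 2 to compound 3 (within the scatter) is small. Compound 3 is therefore estimated at 30%, with a range from 15% to 45%.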

Compound 3, a percentage reported as inhibition, at one concentration (the size of the read-out at that concentration, not a potency): 12%
Compound 3: middle estimate off by 18 percentage points, on the high side, outside the stated range (below it).
By their numbers in this assay, from the lowest: compound 3; then compounds 1 and 2 (each within the scatter of the next).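

In this assay, the place on the amide-type nitrogen in a ring proves sensitive to the arrangement of groups on its phenyl ring: 3-fluoro-2-methoxyphenyl in place of 5-fluoro-2-methoxyphenyl gives a number 20 percentage points lower from compound 2 to compound 3 (beyond the scatter), although both groups hold the same atoms. The exchange of 2-methoxy-5-methylphenyl for 3-fluoro-2-methoxyphenyl gives a step of similar size, a number 18 percentage points lower from compound 1 to compound 3 (beyond the scatter), whereas the earlier exchange of methyl for fluoro stayed within the scatter. Across these three compounds, then, moving the fluorine goes with a step beyond the scatter, while the one exchange that kept the arrangement did not. Nothing available on these compounds accounts for this difference.

The compounds shown leave open whether the lower number is tied to fluorine itself or would also appear with another group in its place, such as chloro or methyl in 3-chloro-2-methoxyphenyl or 2-methoxy-3-methylphenyl. They also leave open how 4-fluoro-2-methoxyphenyl would read, and whether the step would persist with a shorter chain in place of the phenylbutyl chain on the amide.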